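The compounds below may be only part of what the source reports. "The series", "measured", "known", "first", "only" and "open" are said of these compounds alone.

Measured so far:
compound 1, `COc1cc(CSc2ccc3c(C)cc(=O)oc3c2)c([N+](=O)[O-])cc1OC`: > 25800 nM
compound 2, `CCc1cc(=O)c2ccc(OC)c(CBr)c2o1`: > 33600 nM

In a functional assay on KBVIN cells (Homo sapiens) for antiproliferative activity, read by sulforhodamine B assay, with a stated time of 72 h (a higher number here means a weaker inhibitor of growth, a lower number a stronger inhibitor of growth), compound 1 gives only a limit, > 25800 nM. Among the compounds with values here, compound 2 likewise gives only a limit in this assay, > 33600 nM, so its standing is a boundary and not a number; it sits at the limit of > 33600 nM in this assay, at which 1 of the 2 values shown sits, and no measured step leads to or from it. Compound 3, `CCc1cc(=O)c2ccc(OC(C)C)c(CBr)c2o1`, differs from compound 2 by isopropyl in place of methyl on an oxygen on an aromatic ring. No measured step sizes this change; the step from compound 2 to compound 3 is expected as a step that the limit leaves unreadable from compound 2 to compound 3, not beyond the scatter. Compound 3 is expected near 40000 nM in this assay, between 15000 nM and 110000 nM, most likely again as a limit.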

Compound 3, concentration for 50% growth inhibition: > 30700 nM
Compound 3 was reported as a limit; the forecaster's own chance of this, stated with the estimate: 75%; the middle value is on the limit's open side.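

Within the data shown here, compound 3 gives the limit > 30700 nM and compound 2 also gives only a limit, so no step from methoxy to isopropoxy can be read between them. The compounds shown leave open the size of this change, and whether any change to the shared core gives a number instead of a limit.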